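Amide variation on a stilbene cinnamide scaffold

The compounds below may be only part of what the source reports. "The series", "measured", "known", "first", "only" and "open" are said of these compounds alone.

Measured compounds in a functional assay on MCF7 cells (Homo sapiens) for inhibition, read by MTT assay, with a stated time of 48 h; on this read-out higher numbers stand for weaker inhibition and lower numbers for stronger inhibition:
- compound 1 `CCNC(=O)/C=C/c1c(/C=C/c2ccc(OC)cc2)cc(OC)cc1OC` gives 7060 nM
- compound 2 `COc1ccc(/C=C/c2cc(OC)cc(OC)c2/C=C/C(=O)N2CCCCC2C)cc1` gives 4350 nM
- compound 3 `CCCCN(CCCC)C(=O)/C=C/c1c(/C=C/c2ccc(OC)cc2)cc(OC)cc1OC` gives 3990 nM

The three compounds share one core and differ only in the amine on the carbonyl carbon. Compound 3 carries the lowest of the three numbers in this assay, yet every step separating it from the others is within the scatter: a 1.8-fold lower number from compound 1 to compound 3 (0.25 log units; within the scatter) and a 1.1-fold lower number from compound 2 to compound 3 (0.04 log units; within the scatter). The remaining step, a 1.6-fold lower number from compound 1 to compound 2 (0.21 log units; within the scatter), is likewise within the scatter, so on the numbers in hand the three amides are indistinguishable.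

Compound 4 `CCCCCCNC(=O)/C=C/c1c(/C=C/c2ccc(OC)cc2)cc(OC)cc1OC` is the next member. It differs from compound 3 as follows: hexylamino in place of dibutylamino on a carbonyl carbon. Going by the values given here, the step that bears most directly on this change is the one from compound 1 to compound 3, where an ethylamino gave way to dibutylamino; that step was within the scatter, and the present change largely reverses it, returning to a secondary amide while keeping a longer chain. Among the compounds with values here, no step among the measured compounds exceeded the scatter, so no step beyond the scatter is expected here either, and the number for compound 4 is expected to sit near those of compounds 1 to 3. The estimated step is a 1.3-fold higher number from compound 3 to compound 4 (0.10 log units; within the scatter). Compound 4 is therefore estimated at 5000 nM, with a range from 2500 nM to 10000 nM.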

Compound 4, half-maximal inhibitory concentration: 5530 nM
Beside the measured number, compound 4's estimate is 1.1-fold (0.04 log units) below it; low and high end bracket the measured number.
By their numbers in this assay, from the lowest: compounds 3, 2, 4 and 1 (each within the scatter of the next).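

In this assay the change at this carbonyl carbon now includes a secondary amide with a long chain: hexylamino brings back the hydrogen-bond donor that dibutylamino lacks, and the step is a 1.4-fold higher number from compound 3 to compound 4 (0.14 log units; within the scatter) with no move beyond the scatter. The same holds against the ring of 2-methylpiperidin-1-yl, at a 1.3-fold higher number from compound 2 to compound 4 (0.10 log units; within the scatter) and also for butyl in place of hydrogen on a saturated chain carbon, two bonds along the chain from an amide-type nitrogen, at a 1.3-fold lower number from compound 1 to compound 4 (0.11 log units; within the scatter) so neither the donor nor this chain extension separates the amides here. No evidence is at hand to explain this.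

The compounds shown leave open whether any group at this position gives a step beyond the scatter. A morpholine amide, a chain ending in a carboxylic acid or a primary amine, or a chain longer than hexyl could test that.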